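A few compounds are considered here, and "the series" means these few. Any claim that something is new, unique, unknown or untested is made for them only; others in the source may bear on it.

Compound 1, with the structure `Cn1c(/C=C/C(=O)c2ccccc2)cc(Br)c1Br`, is a chalcone-like molecule built on a dibrominated pyrrole core. In a functional assay on PA-1 cells (Homo sapiens) for cytotoxicity, read by MTT assay, with stated times of 6 h and 48 h (on this read-out higher numbers stand for weaker inhibition and lower numbers for stronger inhibition), compound 1 gives >= 100000 nM, which is a limit of the assay rather than a measured number. Compound 2, with the structure `Cn1c(/C=C/C(=O)c2ccc(O)cc2)cc(Br)c1Br`, carries one extra group: hydroxy in place of hydrogen on an aromatic carbon. This single change gives an at least 35-fold lower number from compound 1 to compound 2 (1.54 log units; beyond the scatter), so in this assay compound 2 reaches 2850 nM.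

Compound 3, with the structure `Cn1c(-c2cc(-c3ccccc3)no2)cc(Br)c1Br`, keeps the same dibrominated pyrrole but attaches the phenyl ring through a different linking portion; the difference between the two cores is not broken down here. In this assay compound 3 gives >= 100000 nM, again a limit and not a number. Taken together, (the limit of >= 100000 nM in this assay, at which 2 of the 3 values shown sit), which leaves the true potency of both unsubstituted compounds open.

Compound 4, with the structure `Cn1c(-c2cc(-c3ccccc3O)no2)cc(Br)c1Br`, stands to compound 3 as compound 2 stands to compound 1: hydroxy in place of hydrogen on an aromatic carbon. The change is the same kind of change but not the same one, since in compound 2 the hydroxy sits para to a large group and in compound 4 it sits ortho to a large group, and the core around it is different.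

The estimated step is an at least 6.6-fold lower number from compound 3 to compound 4 (0.82 log units; beyond the scatter), resting on the measured step of an at least 35-fold lower number from compound 1 to compound 2 (1.54 log units; beyond the scatter) and on the fact that compound 3 starts from a limit. Compound 4 is therefore expected to reach about 15000 nM in this assay, within a range from 2500 nM to 100000 nM.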

Compound 4, half-maximal inhibitory concentration: >= 100000 nM
Compound 4: a limit, no number; the forecaster's own chance of this, stated with the estimate: 35%; middle value at least 6.6-fold (0.82 log units) from the limit.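

In this assay, no step can be read from compound 3 to compound 4, because each of the two sits at a limit of the assay and neither has a number: the limit of >= 100000 nM in this assay, at which 3 of the 4 values shown sit.

The compounds shown leave open whether hydroxy in place of hydrogen on an aromatic carbon changes potency at all on the core of compound 3, and how potent compound 1, compound 3 and compound 4 truly are.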